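Removing one methoxy from the trimethoxy ring of compound 1

The compounds below may be only part of what the source reports. "The series", "measured", "known", "first", "only" and "open" are said of these compounds alone.

Within the data shown here, compound 1 `COc1ccc(C[S+]([O-])c2ncccc2C(=O)Nc2ccncc2)c(OC)c1OC` is the only compound here with a numerical result in an ADME assay (a higher number here means that the compound lasts longer, a lower number that the compound disappears faster), where compound 1 gives 0.45 h. Compound 2 `COc1cc(OC)c(OC)cc1C[S+]([O-])c1ncccc1C(=O)Nc1ccncc1` reaches only a limit of this assay, at < 0.02 h, as noted in the limit of < 0.02 h in this assay, at which 1 of the 2 values shown sits. Compound 3 `COc1ccc(C[S+]([O-])c2ncccc2C(=O)Nc2ccncc2)c(OC)c1` differs from compound 1 in a single place, (hydrogen in place of methoxy on an aromatic carbon). Among the measured compounds shown here, with no measured step of this kind to lean on, the author expects the change to stay close to compound 1, within the usual scatter, so the estimated step is a 1.1-fold higher number from compound 1 to compound 3 (0.05 log units; within the scatter). Compound 3 is therefore estimated at 0.5 h, with a likely range from 0.2 h to 1.2 h.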

Compound 3, half-life: < 0.02 h
Compound 3: only a limit was reported; the forecaster's own chance of this, stated with the estimate: 5%; middle value at least 25-fold (1.39 log units) away from the limit.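

Among these compounds, replacing this methoxy with hydrogen gives an at least 22-fold lower number from compound 1 to compound 3 (1.35 log units; beyond the scatter), so in this assay this position, ortho to two methoxy groups, is far from neutral, and the single change is enough to take compound 1 out of the measurable range. Compound 3, like compound 2, gives only a limit, so the step between those two cannot be read: the limit of < 0.02 h in this assay, at which 2 of the 3 values shown sit.

The compounds shown leave open whether a smaller group here, such as fluorine or hydroxyl, would hold the half-life of compound 1. They also leave open how far below the limit compound 3 lies.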